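Swapping the sulfur group on a cytotoxic compound

The compounds below may be only part of what the source reports. "The series", "measured", "known", "first", "only" and "open" are said of these compounds alone.

Measured so far in a functional assay on SW-620 cells (Homo sapiens) for cytotoxicity, read by MTT assay, with stated times of 4 h and 72 h, tested at 2 uM; on this read-out higher numbers stand for weaker inhibition and lower numbers for stronger inhibition:
Compound 1 `COc1ccc(/C=C/C(=O)c2ccc(Nc3cc(C)nc4nc(SCc5nc6ccccc6[nH]5)nn34)cc2)cc1` gives 170 nM
Compound 2 `Cc1cc(Nc2ccc(C(=O)/C=C/c3ccc4ccccc4c3)cc2)n2nc(SCc3cccc4ccccc34)nc2n1` gives 68 nM

Going by the values given here, only two numbers are available, and compound 2 has the lower one, which means stronger inhibition. Its gap to compound 1 goes beyond the usual scatter of repeated measurements. Among the compounds with values here, these two compounds differ in more than one place, so no measured step isolates a single change.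

The next compound, compound 3 `Cc1cc(Nc2ccc(C(=O)/C=C/c3ccc4ccccc4c3)cc2)n2nc(SC(=O)c3csc4ccc(Cl)cc34)nc2n1`, keeps everything in compound 2 except one group. It carries (5-chloro-1-benzothiophen-3-yl)carbonyl in place of (naphthalen-1-yl)methyl on a sulfur.

Within the data shown here, with no direct precedent for this swap, only a cautious expectation is possible. Compound 1 has a different group on that sulfur and differs elsewhere too, yet it still reaches 170 nM in this assay and so offers a loose guide. A small rise in the number, not clearly beyond the scatter, is expected for the estimated step of a 1.9-fold higher number from compound 2 to compound 3 (0.28 log units; within the scatter) in this read-out. Compound 3 is estimated at 130 nM (range 35 nM to 500 nM).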

Compound 3, half-maximal inhibitory concentration: 35 nM
For compound 3 the middle estimate is 3.7-fold (0.57 log units) above the measured one; measured number inside the range.
By their numbers in this assay, from the lowest: compounds 3 and 2 (each within the scatter of the next); then compound 1.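

Going by these compounds alone, this is the first step in which the group on the sulfur changes alone, and in this assay it reads (a 1.9-fold lower number from compound 2 to compound 3 (0.29 log units; within the scatter)), so this read-out does not tell compound 2 and compound 3 apart. The position therefore accepts a quite different group without the number moving beyond the scatter: (naphthalen-1-yl)methyl, made of carbon only and with 0 hydrogen-bond acceptors, gives way to (5-chloro-1-benzothiophen-3-yl)carbonyl, which has a five-membered aromatic ring with 1 hetero atom, a chlorine, a carbonyl and 2 hydrogen-bond acceptors. No measurement at hand says what lies behind this result.

From the compounds shown here alone, the carbonyl, the chlorine and the ring all change together in this one step, so the share of each in the result remains open. A plain benzyl group or a short chain ending in an amine on the same sulfur would test whether this position needs a two-ring aromatic group at all, or whether it accepts almost anything.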